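This account rests on a few compounds, and the source may have more. Where it says the series, first, only, none or still open, it means among the compounds named here.

Of the compounds shown here, two sharing one core have been tested so far in an ADME assay on Raji cells (Homo sapiens) for cytotoxicity, with a stated time of 72 h; a lower number here means that less compound is needed, a higher number that more compound is needed for the effect. Compound 1 `Cc1cc(NC(=O)Nc2ccccc2OC(F)(F)F)c2ccccc2n1` gives > 25000 nM, which is a limit of the assay and not a number. Compound 2 `Cc1cc(NC(=O)Nc2ccc(N)cc2)c2ccccc2n1` gives > 25000 nM, which is also a limit and not a number. Compound 2 thus stands at the limit of > 25000 nM in this assay, at which 2 of the 2 values shown sit, so no exact value is known for it.

The next compound, compound 3 `Cc1cc(NC(=O)Nc2ccccc2F)c2ccccc2n1`, changes one end of the molecule, with 2-fluorophenyl in place of 4-aminophenyl on an amide-type nitrogen. Among the compounds with values here, no step between measured compounds is available to show how large such a change might be. The expectation therefore rests on the two limits alone, and no change beyond the usual scatter is expected in this assay, in either direction. The expected size of the change is a number no higher from compound 2 to compound 3 (the limit leaves the size open). Compound 3 will most likely also reach the limit of the assay and return no exact number. For compound 3 the estimated half-maximal effective concentration is 25000 nM, with an expected range from 8000 nM to 60000 nM.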

Compound 3, half-maximal effective concentration: > 25000 nM
Compound 3 gave a limit, no number; the forecaster's own chance of this, stated with the estimate: 85%; the middle value sits exactly at the limit.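

In this assay compound 3 gives > 25000 nM, a limit and not a number. No step from compound 3 to compound 1 or compound 2 can be read, because all three compounds share one limit: the limit of > 25000 nM in this assay, at which 3 of the 3 values shown sit.

The compounds shown leave open what exact concentration any of them would need, and which group on the shared core would give a measurable number.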